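This account rests on a few compounds, and the source may have more. Where it says the series, first, only, none or still open, it means among the compounds named here.

Measured in a functional assay on A549 cells (Homo sapiens) for antiproliferative activity, read by MTT assay, with a stated time of 24 h; a higher number here means a weaker inhibitor, a lower number a stronger inhibitor:
compound 1, `O=c1[nH]cc(S(=O)(=O)Nc2ccccc2-c2cn(-c3cccc(F)c3)nn2)c(=O)[nH]1`: 8130 nM
compound 2, `O=c1[nH]cc(S(=O)(=O)Nc2ccccc2-c2cn(-c3ccc(F)cc3)nn2)c(=O)[nH]1`: 6390 nM
compound 3, `O=c1[nH]cc(S(=O)(=O)Nc2cccc(-c3cn(-c4cccc(F)c4)nn3)c2)c(=O)[nH]1`: 7200 nM

Compound 1 and compound 2 share a core and differ only by 4-fluorophenyl in place of 3-fluorophenyl on an aromatic nitrogen; in this assay this change gave a 1.3-fold lower number from compound 1 to compound 2 (0.10 log units; within the scatter). Compound 3 carries a core of its own, and the difference between its core and that of compound 1 is not broken down here; its value and that of compound 2 lie within the scatter of one another, as do its value and that of compound 1. Compound 4, `O=c1[nH]cc(S(=O)(=O)Nc2cccc(-c3cn(-c4ccc(F)cc4)nn3)c2)c(=O)[nH]1`, differs from compound 3 by 4-fluorophenyl in place of 3-fluorophenyl on an aromatic nitrogen, the same change that turned compound 1 into compound 2. Compound 4 is therefore expected to show a step of a 1.3-fold lower number from compound 3 to compound 4 (0.11 log units; within the scatter), an expectation resting on the step seen from compound 1 to compound 2, a 1.3-fold lower number from compound 1 to compound 2 (0.10 log units; within the scatter). The estimated value for compound 4 is 5600 nM, expected to fall between 2800 nM and 11000 nM.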

Compound 4, half-maximal inhibitory concentration: > 20000 nM
Compound 4 gave a limit, no number (the forecaster's own chance of this, stated with the estimate: 5%); middle value at least 3.5-fold (0.55 log units) away from the limit.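

In this assay, going by these compounds, the change to 4-fluorophenyl in place of 3-fluorophenyl on the core of compound 3 gave an at least 2.7-fold higher number from compound 3 to compound 4 (0.44 log units; beyond the scatter), and it did not carry over unchanged between the two cores: the same change on two cores in this assay, a 1.3-fold lower number (0.10 log units; within the scatter) from compound 1 to compound 2 and an at least 2.7-fold higher number (0.44 log units; beyond the scatter) from compound 3 to compound 4, at least 3.5-fold (0.54 log units) apart, beyond the scatter of two such steps Compound 4 gave > 20000 nM, which is a limit of the assay and not a number, so the full size of this step remains unknown. The two pairs show that the outcome of this change differed with the core, but they do not give a reason for this or a rule for any other core.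

On these data alone, it remains open how a plain phenyl or a benzyl group on the same aromatic nitrogen would behave on each core. As far as these compounds go, it also remains open whether either would follow compound 2 or compound 4.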